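A few compounds are considered here, and "the series" means these few. Any claim that something is new, unique, unknown or untested is made for them only; others in the source may bear on it.

Measured in an ADME assay on MDCK cells (Canis lupus familiaris) for cytotoxicity; on this read-out lower numbers stand for higher toxicity in this test and higher numbers for lower toxicity in this test:
- compound 1 `O=[N+]([O-])C1=NNc2ncnn2C1c1ccc(O)c(O)c1`: > 1630000 nM, a limit of the assay
- compound 2 `O=[N+]([O-])C1=NNc2nc(C(F)(F)F)nn2C1c1ccc(O)c(O)c1`: 183000 nM
- compound 3 `O=[N+]([O-])C1=NNc2nc(C(F)(F)F)nn2C1c1ccc(O)cc1O`: 108000 nM

Within the data shown here, only two of these values are true numbers, and they lie within the scatter of each other, as a 1.7-fold lower number from compound 2 to compound 3 (0.23 log units; within the scatter) shows. Compound 2 therefore has no clear place above or below compound 3. Compound 1 gives only a limit.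

Compound 4 `CSc1nc2n(n1)C(c1ccc(O)c(O)c1)C([N+](=O)[O-])=NN2` has not yet been measured. It differs from compound 2 by methylsulfanyl in place of trifluoromethyl on an aromatic carbon.

Among the measured compounds shown here, no measured compound carries methylsulfanyl, so the evidence is indirect. The step that bears most closely on the change is an at least 8.9-fold lower number from compound 1 to compound 2 (0.94 log units; beyond the scatter), where trifluoromethyl replaces hydrogen on the same aromatic carbon. That size is a bound and not an exact figure. The step of a 1.7-fold lower number from compound 2 to compound 3 (0.23 log units; within the scatter) changes another part of the molecule and says little here. Losing the trifluoromethyl might undo part of the drop seen in an at least 8.9-fold lower number from compound 1 to compound 2 (0.94 log units; beyond the scatter), so a modest move to a higher number in this assay is expected, though not the full return.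

The expected change is a 2.2-fold higher number from compound 2 to compound 4 (0.34 log units; beyond the scatter).

For compound 4 the estimated value is 400000 nM, with an expected range from 120000 nM to 1300000 nM.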

Compound 4, half-maximal cytotoxic concentration: 362000 nM
Beside the measured number, compound 4's estimate is 1.1-fold (0.04 log units) above it; the measured number falls inside the stated range.
By their numbers in this assay, from the lowest: compounds 3, 2 and 4 (each within the scatter of the next, the first and the last beyond it). At a limit, above all of these: compound 1.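

In this assay, the carbon between two ring nitrogen atoms accepts a change of substituent with little effect on the read-out: a 2.0-fold higher number from compound 2 to compound 4 (0.30 log units; within the scatter). The earlier compounds shown here showed only what trifluoromethyl did in place of hydrogen, whereas methylsulfanyl now gives a second case, with an at least 4.5-fold lower number from compound 1 to compound 4 (0.65 log units; beyond the scatter), so a number clearly under that of the hydrogen compound does not depend on trifluoromethyl alone. The size of this second step is only a bound, because compound 1 stands at a limit of the assay: the limit of > 1630000 nM in this assay, at which 1 of the 4 values shown sits.

The compounds shown leave open how far the number of the hydrogen compound truly lies from the substituted ones, and whether other groups on this carbon, such as an amine or a longer chain like ethylsulfanyl, would fall with trifluoromethyl and methylsulfanyl or nearer to hydrogen. They also leave open whether methylsulfanyl reads the same with the 2,4-dihydroxyphenyl of compound 3, since the methylsulfanyl group is seen here only with 3,4-dihydroxyphenyl.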